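A few compounds are considered here, and "the series" means these few. Any claim that something is new, unique, unknown or untested is made for them only; others in the source may bear on it.

Measured so far in a functional assay for agonist activity at G protein-coupled receptor 88 (Homo sapiens), read by HTRF and cAMP accumulation; a higher number here means that more compound is needed for the effect, a lower number that less compound is needed:
Compound 1 `CN[C@@H](CC(C)C)CN(C(=O)[C@@H]1C[C@H]1c1ccccc1)c1ccc(-c2ccccc2)cc1`: compound 1 gives 2 nM
Compound 2 `CC(C)[C@H](N)CN(C(=O)[C@@H]1C[C@H]1c1ccccc1)c1ccc(-c2ccccc2)cc1`: compound 2 gives 1.1 nM
Compound 3 `NC1(CN(C(=O)[C@@H]2C[C@H]2c2ccccc2)c2ccc(-c3ccccc3)cc2)CCCC1`: compound 3 gives 0.57 nM

Compound 3 sits at the low end of these three numbers. Its separation from compound 2, a 1.9-fold lower number from compound 2 to compound 3 (0.29 log units; within the scatter), is within the scatter, so the two cannot be ordered; only its separation from compound 1, a 3.5-fold lower number from compound 1 to compound 3 (0.55 log units; beyond the scatter), is beyond the scatter.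

Compound 4 `CC(C)CCNCCN(C(=O)[C@@H]1C[C@H]1c1ccccc1)c1ccc(-c2ccccc2)cc1` differs from compound 3 by (isopentylamino)methyl in place of 1-aminocyclopentyl on a saturated chain carbon bound to an amide-type nitrogen.

Bearing on this step: the move from the open, alpha-branched methylamino chain of compound 1 to the cyclopentyl of compound 3 gave a 3.5-fold lower number from compound 1 to compound 3 (0.55 log units; beyond the scatter), a modest gain. For the measured compounds named here, the move from compound 3 to compound 4 undoes that ring and also removes the alpha-branching, replacing it with a longer alkyl on the nitrogen; none of the measured compounds tests that last part. The steps of a 1.8-fold lower number from compound 1 to compound 2 (0.26 log units; within the scatter) and a 1.9-fold lower number from compound 2 to compound 3 (0.29 log units; within the scatter) stayed within the scatter, so the ring itself seems the stronger lever. A modest rise in this assay is therefore expected, of about a 5.3-fold higher number from compound 3 to compound 4 (0.72 log units; beyond the scatter), with the untested chain adding uncertainty.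

Compound 4 is estimated at 3 nM, expected between 0.8 nM and 12 nM.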

Compound 4, half-maximal effective concentration: 5.1 nM
Estimate against measurement, compound 4: 1.7-fold (0.23 log units) below; measured number inside the range.
By their numbers in this assay, from the lowest: compounds 3, 2 and 1 (each within the scatter of the next, the first and the last beyond it); then compound 4.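

In this assay, for the compounds shown here, (isopentylamino)methyl in place of 1-aminocyclopentyl, on a saturated chain carbon bound to an amide-type nitrogen, gives an 8.9-fold higher number from compound 3 to compound 4 (0.95 log units; beyond the scatter), the largest step so far. The other two steps are also beyond the scatter: a 4.6-fold higher number from compound 2 to compound 4 (0.67 log units; beyond the scatter) and a 2.6-fold higher number from compound 1 to compound 4 (0.41 log units; beyond the scatter), which places compound 4 at the high end of the four numbers. Compound 1 and compound 2 have no ring in this group either, so losing the ring does not by itself describe the whole rise, and the unbranched 2-(isopentylamino)ethyl chain now stands as a separate change in its own right. No measurement at hand gives a reason for these steps.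

On these data alone, the share of the rise that belongs to the isopentyl group on the nitrogen, as against the unbranched ethyl link, remains open, and a plain 2-aminoethyl or 2-(methylamino)ethyl group in this place would separate the two. The compounds shown also leave open how far the ring size matters, a question that 1-aminocyclobutyl and 1-aminocyclohexyl would address.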